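The source may report more compounds than this note shows. Statements on the series, on what has been measured and on what is new or still open speak of the compounds shown alone.

Measured compounds:
compound 1, `CCC1C(=O)N(C)c2cnc(-n3ccc4cc(C(=O)NCC(C)C)ccc43)nc2N1c1ccn(C)n1`, 5600 nM
compound 2, `CCCCNC(=O)c1ccc2c(ccn2-c2ncc3c(n2)N(c2ccn(C)n2)C(CC)C(=O)N3C)c1`, 14100 nM

In a functional assay on K562 cells (Homo sapiens) for antiproliferative activity, read by CCK-8 assay, with a stated time of 72 h (a lower number here means a stronger inhibitor of growth, a higher number a weaker inhibitor of growth), compound 2 stands highest of the two numbers shown; the step of a 2.5-fold higher number from compound 1 to compound 2 (0.40 log units; beyond the scatter) is the only measured step, and it links compound 2 to compound 1 by a change at the same amide chain. Compound 3, `CCCNC(=O)c1ccc2c(ccn2-c2ncc3c(n2)N(c2ccn(C)n2)C(CC)C(=O)N3C)c1`, follows from compound 2 by a different change: hydrogen in place of methyl on a saturated chain carbon, three bonds along the chain from an amide-type nitrogen. Within the data shown here, no measured step tests this shortening of the chain, so the measured step bears on it only loosely. Compound 3 is expected to lie close to compound 2, with a step of a 1.2-fold lower number from compound 2 to compound 3 (0.07 log units; within the scatter), and its estimated value is 12000 nM, within 5000 nM to 30000 nM.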

Compound 3, concentration for 50% growth inhibition: 8270 nM
Compound 3: middle estimate off by 1.5-fold (0.16 log units), on the high side; the measured number falls inside the stated range.
By their numbers in this assay, from the lowest: compounds 1, 3 and 2 (each within the scatter of the next, the first and the last beyond it).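

Within this assay the change from butyl to propyl on the amide gives a 1.7-fold lower number from compound 2 to compound 3 (0.23 log units; within the scatter) and leaves the number within the scatter. Hydrogen in place of methyl on a saturated chain carbon bound to two saturated chain carbons gives a 1.5-fold higher number from compound 1 to compound 3 (0.17 log units; within the scatter) and also stays within the scatter, so compound 3 separates from neither neighbour, although compound 1 and compound 2 lie apart beyond the scatter. Nothing available explains these numbers. Going by these compounds, whether a shorter chain such as ethyl, a longer chain, an amine or a carboxylic acid at this amide would shift the number beyond the scatter remains open.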